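The compounds below may be only part of what the source reports. "The series", "measured", "known", "first", "only" and "open" are said of these compounds alone.

In a functional assay on MIA PaCa-2 cells (Homo sapiens) for inhibition, read by MTT assay, with a stated time of 3 days (a higher number here means a weaker inhibitor, a lower number a stronger inhibitor), compound 1 `CCN(CC)S(=O)(=O)c1ccc(S(=O)(=O)N2CCC[C@@H](C(=O)N[C@H]3CC[C@H](OC)CC3)C2)cc1` gives 2290 nM and compound 2 `CCN(CC)S(=O)(=O)c1ccc(S(=O)(=O)N2CCC[C@@H](C(=O)N3CCC(COC)CC3)C2)cc1` gives 50 nM while compound 3 `CCN(CC)S(=O)(=O)c1ccc(S(=O)(=O)N2CCC[C@@H](C(=O)N3CC[C@@H](OC)C3)C2)cc1` gives 1070 nM as the middle of the three numbers. Its position is set by two steps: a 2.1-fold lower number from compound 1 to compound 3 (0.33 log units; beyond the scatter) is modest and a 21-fold higher number from compound 2 to compound 3 (1.33 log units; beyond the scatter) is large. Against compound 3, compound 4 `CCN(CC)S(=O)(=O)c1ccc(S(=O)(=O)N2CCC[C@@H](C(=O)N3CC[C@H](OC)C3)C2)cc1` shows the two compounds have the same atoms and bonds and differ only in configuration as drawn: 1 of 2 stereo elements differ; a stereocentre at a saturated ring carbon is drawn R in compound 3 and S in compound 4 and here a stereocentre at a saturated ring carbon is drawn R in compound 3 and S in compound 4. Among the compounds with values here, no measured step is a change of configuration alone, so the measured steps bear only loosely: each replaces the whole group on the carbonyl carbon, and a 46-fold lower number from compound 1 to compound 2 (1.66 log units; beyond the scatter) is the largest such move. A step within the scatter, with no favoured direction, is therefore expected in this assay but with a wide margin. The expected step is a 1.1-fold lower number from compound 3 to compound 4 (0.03 log units; within the scatter) in size. Compound 4 is estimated at 1000 nM with an expected range from 250 nM to 4000 nM.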

Compound 4, half-maximal inhibitory concentration: 460 nM
Estimate against measurement, compound 4: 2.2-fold (0.34 log units) above, and the stated range covers the measured number.
By their numbers in this assay, from the lowest: compound 2; then compound 4; then compound 3; then compound 1.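

In this assay, a change at a single stereocentre on a saturated ring carbon moves the number on its own, with a 2.3-fold lower number from compound 3 to compound 4 (0.37 log units; beyond the scatter), and the comparison is clean: the fact that compounds 3 and 4 differ only in the configuration as drawn

Drawn S, the 3-methoxypyrrolidin-1-yl group still falls short of 4-(methoxymethyl)piperidin-1-yl, with a 9.2-fold higher number from compound 2 to compound 4 (0.96 log units; beyond the scatter), while its gain over (4-methoxycyclohexyl)amino grows, with a 5.0-fold lower number from compound 1 to compound 4 (0.70 log units; beyond the scatter).

The compounds shown leave open whether this preference for S survives when the methoxy group is replaced by a hydroxyl or an ethoxy group, or by an amine.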